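A few compounds are considered here, and "the series" means these few. Any claim that something is new, unique, unknown or untested is made for them only; others in the source may bear on it.

Three analogues share one core and were compared in a functional assay on MCF7 cells (Homo sapiens) for antiproliferative activity; on this read-out higher numbers stand for weaker inhibition and lower numbers for stronger inhibition. Compound 1 `CC(C)=CCc1cc(C(=O)Nc2cc3ccc(Oc4ccc(C(C)(C)C)cc4)c(C)c3oc2=O)ccc1O` gives 20600 nM. Compound 2 `COc1cccc(Cc2ccc3cc(NC(=O)c4ccc(O)c(CC=C(C)C)c4)c(=O)oc3c2C)c1` gives 19700 nM, and compound 3 `COc1ccc(Cc2ccc3cc(NC(=O)c4ccc(O)c(CC=C(C)C)c4)c(=O)oc3c2C)cc1OC` gives 13900 nM, the lowest of the three numbers, though the gaps to compound 2 and compound 1 both lie within the scatter. Compound 4 `CC(C)=CCc1cc(C(=O)Nc2cc3ccc(Cc4ccc(O)cc4)c(C)c3oc2=O)ccc1O` is not yet measured; it differs from compound 3 by 4-hydroxyphenyl in place of 3,4-dimethoxyphenyl on a saturated chain carbon bound to an aromatic carbon. The step most closely related is a 1.4-fold lower number from compound 2 to compound 3 (0.15 log units; within the scatter), and the larger replacements a 1.0-fold lower number from compound 1 to compound 2 (0.02 log units; within the scatter) and a 1.5-fold lower number from compound 1 to compound 3 (0.17 log units; within the scatter) also stayed within the scatter. On this evidence no step beyond the scatter is expected, a 1.2-fold higher number from compound 3 to compound 4 (0.09 log units; within the scatter). Compound 4 is therefore estimated at 17000 nM, within 7000 nM to 40000 nM.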

Compound 4, half-maximal inhibitory concentration: 32100 nM
Beside the measured number, compound 4's estimate is 1.9-fold (0.28 log units) below it, and the stated range covers the measured number.
By their numbers in this assay, from the lowest: compounds 3, 2, 1 and 4 (each within the scatter of the next, the first and the last beyond it).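

In this assay, for the compounds shown here, 4-hydroxyphenyl in place of 3,4-dimethoxyphenyl gives the only step beyond the scatter, a modest one: a 2.3-fold higher number from compound 3 to compound 4 (0.36 log units; beyond the scatter). Against the other two analogues the same compound stays within the scatter, with a 1.6-fold higher number from compound 2 to compound 4 (0.21 log units; within the scatter) and a 1.6-fold higher number from compound 1 to compound 4 (0.19 log units; within the scatter), so at this position the difference shows only against the dimethoxy analogue. Nothing available explains this step. The compounds shown leave open how 4-methoxyphenyl or 4-aminophenyl would read on this saturated chain carbon, and so whether the hydroxy group or the loss of both methoxy groups accounts for the step.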